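Notes on a 2,3-dichlorophenyl exchange in the series

A few compounds are considered here, and "the series" means these few. Any claim that something is new, unique, unknown or untested is made for them only; others in the source may bear on it.

Measured in a functional assay on A549 cells (Homo sapiens) for cytotoxicity, read by MTT assay, with a stated time of 72 h; on this read-out lower numbers stand for stronger inhibition and higher numbers for weaker inhibition
- compound 1 `COc1cccc(/C=C2\CCC/C(=C\c3ccccc3Cl)C2=O)c1OC` gives > 20000 nM (a limit)
- compound 2 `COc1cccc(/C=C2\CCC/C(=C\c3ccccc3Br)C2=O)c1OC` gives > 20000 nM (a limit)
- compound 3 `COc1cccc(/C=C2\CCC/C(=C\c3cccc(OC)c3OC)C2=O)c1` gives 16400 nM (a number)

Within the data shown here, compound 3 with 16400 nM is the only compound here with a true number. The other two values sit at the limit of > 20000 nM in this assay, at which 2 of the 3 values shown sit, and are limits, not numbers.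

Compound 4 `COc1cccc(/C=C2\CCC/C(=C\c3cccc(Cl)c3Cl)C2=O)c1OC` comes from compound 3 by a single exchange (2,3-dichlorophenyl in place of 3-methoxyphenyl on a double-bonded chain carbon bound to a double-bonded ring carbon): 2,3-dichlorophenyl in place of 3-methoxyphenyl on a double-bonded chain carbon bound to a double-bonded ring carbon.

Two measured steps change the same place, there from a halogen-bearing phenyl to 3-methoxyphenyl: an at least 1.2-fold lower number from compound 1 to compound 3 (0.08 log units; that floor lies within the scatter) and an at least 1.2-fold lower number from compound 2 to compound 3 (0.08 log units; that floor lies within the scatter) are floors only, and both lie within the scatter. The third step, a step that the two limits leave unreadable from compound 1 to compound 2, cannot be read.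

Taken in reverse, those two floors suggest a drift toward higher numbers in this assay at most, with no size beyond the scatter. The estimated step is a 1.2-fold higher number from compound 3 to compound 4 (0.09 log units; within the scatter) and is not expected to exceed the scatter. For compound 4 the expected value is 20000 nM, with an estimated range from 9000 nM to 45000 nM in this read-out. A report of only a limit is also quite possible for compound 4.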

Compound 4, half-maximal inhibitory concentration: > 20000 nM
Compound 4 was reported as a limit; the forecaster's own chance of this, stated with the estimate: 60%; the middle value lies on the limit itself.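

In this assay, the exchange at this place, on a double-bonded chain carbon bound to a double-bonded ring carbon, gives an at least 1.2-fold higher number from compound 3 to compound 4 (0.08 log units; that floor lies within the scatter), so it is a floor only and shows no readable change. Among these compounds, the result extends the earlier picture from phenyls carrying one halogen to 2,3-dichlorophenyl: compounds 1, 2 and 4 all stand at the same limit, and compound 3, with 3-methoxyphenyl at this place, is the one compound against that pattern, though its distance from them stays within what the floors can show. The steps among compounds 1, 2 and 4 cannot be read, and adding a second chloro to compound 1 therefore gives no size of effect, with the series now resting on: the limit of > 20000 nM in this assay, at which 3 of the 4 values shown sit.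

From the compounds shown here alone, how far compounds 1, 2 and 4 actually lie from one another, and from compound 3, remains open, as the limits hide their true values. Also open, going by these compounds, is how this read-out would respond to a phenyl carrying an amine or a carboxylic acid at this place.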